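The source may hold more compounds than are shown below. What is called first, only, known or untested is meant among the compounds shown, and "the series" means these compounds.

Measured compounds:
compound 1 `CCCCNc1nc(N)nc(C)c1CCCCc1ccccc1`: 857 nM
compound 2 `CCCCNc1nc(N)nc(C)c1CCCn1c(C)nc2ccccc21`: 366 nM
compound 3 `CCCCNc1nc(N)nc(C)c1CCCN1C(=O)c2ccccc2C1=O`: 453 nM

In an assay on HEK293 cells for agonist activity at Toll-like receptor 8 (Homo sapiens), read by spectrophotometry (on this read-out higher numbers stand for an effect only at larger amounts of compound and lower numbers for an effect already at smaller amounts), compound 1 gives the highest of the three numbers. Compound 3 sits within the scatter of compound 1, while compound 2 lies beyond it, with the lower number. Compound 4 `CCCCNc1nc(N)nc(C)c1CCCCCc1ccccc1` differs from compound 1 in one place: benzyl in place of phenyl on a saturated chain carbon, four bonds along the chain from an aromatic carbon. Going by the values given here, no measured pair shows a step of this kind, so the size of the change is not known from the data; the other two compounds, which carry different groups at the end of a shorter chain, give similar or somewhat lower numbers. The step of a 1.2-fold lower number from compound 1 to compound 4 (0.09 log units; within the scatter) is expected to stay within the scatter. Compound 4 is therefore estimated at 700 nM, in a range from 300 nM to 1700 nM.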

Compound 4, half-maximal effective concentration: 830 nM
The estimate for compound 4 lay 1.2-fold (0.07 log units) below the measured number; the measured number falls inside the stated range.
By their numbers in this assay, from the lowest: compounds 2, 3, 4 and 1 (each within the scatter of the next, the first and the last beyond it).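

In this assay, going by these compounds alone, benzyl in place of phenyl on a saturated chain carbon, four bonds along the chain from an aromatic carbon, gives the first measured step at this position (a 1.0-fold lower number from compound 1 to compound 4 (0.01 log units; within the scatter)). At this place, the read-out does not tell the two groups apart, so the extra carbon of benzyl shows no effect beyond the scatter. Nothing available explains this result.

As far as these compounds go, whether phenethyl or a longer chain would also stay within the scatter remains open. So does whether an amine or a carboxylic acid in place of phenyl would move the number beyond it.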